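A few compounds are considered here, and "the series" means these few. Any claim that something is new, unique, unknown or untested is made for them only; others in the source may bear on it.

Measured compounds in a toxicity assay on GES1 cells (Homo sapiens) for inhibition, read by MTT assay, with a stated time of 72 h; a higher number here means a weaker inhibitor, a lower number a stronger inhibitor:

- compound 1, `Cc1cc(N2CC[C@@H](C)[C@@H](N(C)c3ncnc4[nH]ccc34)C2)n2nc(SCc3ccccc3Br)nc2n1`: > 100000 nM
- compound 2, `Cc1cc(N2CC[C@@H](C)[C@@H](N(C)c3ncnc4[nH]ccc34)C2)n2nc(SCc3ccc(Br)cc3)nc2n1`: 55600 nM
- compound 3, `Cc1cc(N2CC[C@@H](C)[C@@H](N(C)c3ncnc4[nH]ccc34)C2)n2nc(SCc3ccc([N+](=O)[O-])cc3)nc2n1`: 36600 nM

For the measured compounds named here, compound 1 stands only at a limit of this assay, > 100000 nM, and not at a number; it is the one value among the three that sits at the limit of > 100000 nM in this assay, at which 1 of the 3 values shown sits. Compound 2 in this assay gives 55600 nM, and compound 3 gives 36600 nM.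

Compound 4, `Cc1cc(N2CC[C@@H](C)[C@@H](N(C)c3ncnc4[nH]ccc34)C2)n2nc(SCc3ccc(C(F)(F)F)cc3)nc2n1`, differs from compound 1 in one place: 4-(trifluoromethyl)phenyl in place of 2-bromophenyl on a saturated chain carbon bound to a sulfur.

Going by the values given here, two measured steps bear on this change, since both also replace the 2-bromophenyl of compound 1 with a phenyl carrying a single group in the same 4-substituted arrangement: an at least 1.7-fold lower number from compound 1 to compound 2 (0.25 log units; that floor lies within the scatter) and an at least 2.7-fold lower number from compound 1 to compound 3 (0.43 log units; beyond the scatter). Between those two products, a 1.5-fold lower number from compound 2 to compound 3 (0.18 log units; within the scatter). The trifluoromethyl case is thus expected to fall in the same direction, with a step of the order of an at least 2.2-fold lower number from compound 1 to compound 4 (0.34 log units; beyond the scatter), meaning a lower number than the limit of compound 1.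

On that basis compound 4 is estimated at 45000 nM in this assay, with a range from 20000 nM to 110000 nM.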

Compound 4, half-maximal inhibitory concentration: 17300 nM
The estimate for compound 4 lay 2.6-fold (0.42 log units) above the measured number; measured number outside the range, below it.
By their numbers in this assay, from the lowest: compound 4; then compounds 3 and 2 (each within the scatter of the next). At a limit, above all of these: compound 1.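

In this assay, bromo and nitro on the aromatic carbon could not be told apart, but trifluoromethyl on that carbon can be told from both: a 2.1-fold lower number from compound 3 to compound 4 (0.33 log units; beyond the scatter), and a 3.2-fold lower number from compound 2 to compound 4 (0.51 log units; beyond the scatter). The group carried on that aromatic carbon therefore moves this number by steps beyond the scatter, among compounds 2, 3 and 4, which share the rest of the structure. The change away from 2-bromophenyl now reads as an at least 5.7-fold lower number from compound 1 to compound 4 (0.76 log units; beyond the scatter), which is a floor and not a size, and compound 1 is a limit of the assay and not a number: the limit of > 100000 nM in this assay, at which 1 of the 4 values shown sits.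

The compounds shown leave open how a methoxy group, an amine or a carboxylic acid on that aromatic carbon would read. As far as these compounds go, the true size of the step from compound 1 also stays open while its value remains a limit.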